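A few compounds are considered here, and "the series" means these few. Any claim that something is new, unique, unknown or untested is made for them only; others in the source may bear on it.

Compound 1 `S=C(N/N=C/c1cccs1)Nc1ccc(Cl)cc1`: > 100000 nM
Compound 2 `S=C(N/N=C/c1cccs1)Nc1cccc2ccccc12`: > 100000 nM

In a functional assay on NCI-H460 cells (Homo sapiens) for inhibition, read by sulforhodamine B assay, with a stated time of 48 h (a lower number here means a stronger inhibitor of growth, a higher number a weaker inhibitor of growth), compound 1 gives > 100000 nM, which is a limit of the assay and not a number. Compound 2 gives > 100000 nM, which is also a limit. Compound 1 therefore stands at the limit of > 100000 nM in this assay, at which 2 of the 2 values shown sit.

Compound 3 `S=C(N/N=C/c1cccs1)Nc1ccc(Br)cc1` has not yet been measured. It keeps the core of compound 1 and changes one substituent: bromo in place of chloro on an aromatic carbon. Going by the values given here, no pair of measured compounds shows what a change of this kind does in this assay, so no shift in either direction is expected beyond the scatter. The expected step of a number no higher from compound 1 to compound 3 (the limit leaves the size open) is therefore small, though the limit on compound 1 leaves its true size open. Compound 3 is estimated at 100000 nM, with an expected range of 40000 nM to 200000 nM.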

Compound 3, concentration for 50% growth inhibition: 4700 nM
Estimate against measurement, compound 3: 21-fold (1.33 log units) above, and the stated range ends above it.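

On this aromatic carbon, para to a large group, the exchange of one single atom matters: in this assay, bromo in place of chloro gives an at least 21-fold lower number from compound 1 to compound 3 (1.32 log units; beyond the scatter). Compound 1 gives > 100000 nM, which is a limit and not a number, so the step has a known lower bound but no known full size. Compound 3 is the only compound shown with a measured number, and the other two stop at the limit: the limit of > 100000 nM in this assay, at which 2 of the 3 values shown sit.

Going by these compounds alone, this one pair is the only comparison at this place, and it does not tell why bromo and chloro differ here. It also leaves open whether iodo, fluoro, a methyl group or an amine on the same carbon would keep or lose the growth inhibition seen with compound 3.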